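A Formyl Ether Swap on a Shared Core

The source may report more compounds than this note shows. Statements on the series, on what has been measured and on what is new or still open speak of the compounds shown alone.

Two measured compounds share a core and differ in the group attached to the saturated chain carbon. Compound 1 `CCOC(=O)c1c(-c2ccccc2)nn(-c2ccccc2)c1Cn1cnc2cc([N+](=O)[O-])ccc21` carries a nitro-bearing group, and in an assay for inhibition of Alpha amylase (Homo sapiens), with a stated time of 30 min (a lower number here means a stronger inhibitor, a higher number a weaker inhibitor), compound 1 gives 30 ug/mL. Compound 2 `CCOC(=O)c1c(-c2ccccc2)nn(-c2ccccc2)c1COc1ccc(C=O)cc1OC` carries a formyl-bearing phenoxy group, and in this assay compound 2 gives 60 ug/mL, the highest of the two numbers, though its gap to compound 1 lies within the scatter of repeated measurements. Among the compounds with values here, no step between these two has been worked out, so only the two values themselves are known. Compound 3 `CCOC(=O)c1c(-c2ccccc2)nn(-c2ccccc2)c1COc1ccccc1C=O` is reached from compound 2 by the change 2-formylphenyl in place of 4-formyl-2-methoxyphenyl on an oxygen on a saturated carbon. Within the data shown here, with no measured step of this kind to lean on, the expected step of no change at the digits printed from compound 2 to compound 3 (within the scatter) is none beyond the scatter, in no settled direction. Compound 3 is therefore expected to give 60 ug/mL, within 30 ug/mL to 120 ug/mL.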

Compound 3, half-maximal inhibitory concentration: 40 ug/mL
Compound 3: the middle estimate sits 1.5-fold (0.18 log units) above what was measured, within the range that was stated.
By their numbers in this assay, from the lowest: compounds 1, 3 and 2 (each within the scatter of the next).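

In this assay, within the data shown here, exchanging 4-formyl-2-methoxyphenoxy for 2-formylphenoxy gives a 1.5-fold lower number from compound 2 to compound 3 (0.18 log units; within the scatter), the first step that can be read at this position, and the two compounds cannot be told apart on this result. The exchange removes the methoxy group and alters the place of the formyl group in a single step, so the result does not separate one alteration from the other, and the two could be offsetting each other or could both be without consequence here.

From the compounds shown here alone, it stays open how a phenoxy group carrying only the methoxy group, or one with a carboxylic acid, an amine or a nitrile in place of the formyl group, would read on the shared core. Nothing at hand bears on the reason for any of these values.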